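Ethoxycarbonyl in place of the oxamate-type amino group

This account rests on a few compounds, and the source may have more. Where it says the series, first, only, none or still open, it means among the compounds named here.

Measured in a functional assay on the whole organism with Rattus norvegicus as the target; on this read-out lower numbers stand for an effect already at smaller amounts and higher numbers for an effect only at larger amounts of compound:
- Compound 1 `CCOC(=O)C(=O)Nc1nc(-c2ccc(Sc3ccccc3)cc2)cs1`: > 3 mg/kg, a limit
- Compound 2 `CCOC(=O)C(=O)Nc1ccc(-c2csc(NC(=O)C(=O)OCC)n2)cc1`: > 30 mg/kg, a limit

Compound 2 has no number in this assay, only the limit > 30 mg/kg. For the measured compounds named here, the sole other value shown is also a limit, and it belongs to compound 1.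

Compound 3 `CCOC(=O)C(=O)Nc1nc(-c2ccc(C(=O)OCC)cc2)cs1` differs from compound 2 at one place: ethoxycarbonyl in place of ((ethoxycarbonyl)carbonyl)amino on an aromatic carbon. Ethoxycarbonyl stands in place of ((ethoxycarbonyl)carbonyl)amino on an aromatic carbon of a six-membered aromatic ring of carbon only, para to a large group.

Going by the values given here, the one measured step bearing on this place is a step that the two limits leave unreadable from compound 1 to compound 2. It has no readable size, so it gives no magnitude or direction to carry over to the new change. No step beyond the scatter is therefore expected in this assay, though this expectation rests on very little. The estimate amounts to an expected a number no higher from compound 2 to compound 3 (the limit leaves the size open). For compound 3 the estimated value is 30 mg/kg, with an expected range from 6 mg/kg to 100 mg/kg. A limit rather than a number is the more likely outcome.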

Compound 3, dose for half-maximal effect: > 10 mg/kg
Compound 3: a limit, no number; the forecaster's own chance of this, stated with the estimate: 65%; the middle value lies beyond the limit too.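

In this assay compound 3 gives > 10 mg/kg, a limit and no number. Compound 2 and compound 1 also carry only limits, so no step can be read among compound 1, compound 2 and compound 3. The compounds shown leave open what dose for half-maximal effect any of them has in this assay, and how phenylsulfanyl, ((ethoxycarbonyl)carbonyl)amino and ethoxycarbonyl rank.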